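The source may report more compounds than this note shows. Statements on the series, on what has been measured and on what is new or still open speak of the compounds shown alone.

Values so far in a functional assay on HCT-116 cells (Homo sapiens) for antiproliferative activity, read by MTT assay, with a stated time of 48 h; on this read-out higher numbers stand for weaker inhibition and lower numbers for stronger inhibition
- compound 1 `COc1ccc(CN(C(=O)CSc2nc3ccccc3s2)c2cc(OC)c(OC)c(OC)c2)cc1O` gives 182 nM
- compound 2 `COc1ccc(CN(C(=O)CSc2nc3ccccc3s2)c2cc(OC)c(OC)c(OC)c2)cc1[N+](=O)[O-]` gives 1280 nM
- compound 3 `COc1cc(CN(C(=O)CSc2nc3ccccc3s2)c2cc(OC)c(OC)c(OC)c2)cc(OC)c1OC` gives 65300 nM

Compound 1 stands lowest of these three numbers, and both of its steps lie beyond the scatter, with a 7.0-fold higher number from compound 1 to compound 2 (0.85 log units; beyond the scatter) as the modest one and a 360-fold higher number from compound 1 to compound 3 (2.55 log units; beyond the scatter) as the large one. The change to compound 4 `COc1ccc(CN(C(=O)CSc2nc3cc(Cl)ccc3s2)c2cc(OC)c(OC)c(OC)c2)cc1O` is chloro in place of hydrogen on an aromatic carbon and reads in words as chloro in place of hydrogen on an aromatic carbon, so that 1,3-benzothiazol-2-yl becomes 5-chloro-1,3-benzothiazol-2-yl.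

Among the compounds with values here, none of the measured steps touches that part of the molecule. All of them exchange the aryl group on the saturated chain carbon bound to the amide-type nitrogen, and a 51-fold higher number from compound 2 to compound 3 (1.71 log units; beyond the scatter) is a further large one of that kind. Within the data shown here, they show how far the numbers can move at that other place but give no direction for this change, and no chloro compound has been measured yet. With compound 1 at 182 nM as the only reference, no step beyond the scatter is expected in this assay, though the uncertainty is wide. On these data alone, the expected step is a 1.2-fold higher number from compound 1 to compound 4 (0.08 log units; within the scatter) and its direction stays open. For compound 4 220 nM is the estimated value, with an expected range of 60 nM to 800 nM around it.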

Compound 4, half-maximal inhibitory concentration: 429 nM
For compound 4 the middle estimate is 2.0-fold (0.29 log units) below the measured one; measured number inside the range.
By their numbers in this assay, from the lowest: compound 1; then compound 4; then compound 2; then compound 3.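

In this assay, the 1,3-benzothiazol-2-yl group gives the first measured change away from the aryl group on the saturated chain carbon, and adding chloro to form 5-chloro-1,3-benzothiazol-2-yl gives a 2.4-fold higher number from compound 1 to compound 4 (0.37 log units; beyond the scatter). This shows that the number responds to a single chloro on this six-membered aromatic ring, with weaker inhibition than compound 1 but a smaller step than either a 7.0-fold higher number from compound 1 to compound 2 (0.85 log units; beyond the scatter) or a 360-fold higher number from compound 1 to compound 3 (2.55 log units; beyond the scatter) at the aryl group, so this one substitution costs far less than the trimethoxyphenyl exchange. No measurement available here bears on why chloro moves the number in this direction.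

Still open, on these data alone, is whether a fluoro, methoxy, amine or carboxylic acid group at this same aromatic carbon would move the number in the same direction as chloro, or whether the step is specific to chloro. Also open, as far as these compounds go, is whether the step seen with the 3-hydroxy-4-methoxyphenyl group carries over when the 4-methoxy-3-nitrophenyl or 3,4,5-trimethoxyphenyl group takes its place.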